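A few compounds are considered here, and "the series" means these few. Any claim that something is new, unique, unknown or untested is made for them only; others in the source may bear on it.

Compound 3 `CN1CCN(c2ccc(C3=NN(C(=O)/C=C/c4ccccc4)C(c4ccc(N(C)C)cc4)C3)cc2)CC1` gives 71% in a functional assay on HCC1806 cells (Homo sapiens) for inhibition, read by sulforhodamine B assay, tested at 10 uM (a lower number here means less inhibition, a higher number more inhibition at the concentration tested (going by the name of the read-out)), and stands highest of the three measured compounds. Compound 1 `CN(C)c1ccc(C2CC(c3ccc(-n4cncn4)cc3)=NN2)cc1` gives 6.8%, and compound 2 `Cc1ccc(C(=O)N2N=C(c3ccc(N4CCN(C)CC4)cc3)CC2c2ccc(N(C)C)cc2)cc1` gives -2.5%, both far beyond the scatter below compound 3. Among the measured compounds shown here, the one step on the same ring nitrogen, a number 73.5 percentage points higher from compound 2 to compound 3 (beyond the scatter), shows that the group on that nitrogen decides the inhibition. Compound 4 `CN1CCN(c2ccc(C3=NN(S(=O)(=O)c4ccc(C#N)cc4)C(c4ccc(N(C)C)cc4)C3)cc2)CC1` differs from compound 3 by (4-cyanophenyl)sulfonyl in place of (2-phenylethenyl)carbonyl on an amine nitrogen in a ring. For the measured compounds named here, no measured step covers a sulfonyl group here, but the only step at this position was large, so a large loss is expected: compound 4 is expected to give 15%, within -10% to 55%, an expected step of a number 56 percentage points lower from compound 3 to compound 4 (beyond the scatter) toward the level of compound 2.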

Compound 4, a percentage reported as inhibition, at one concentration (the size of the read-out at that concentration, not a potency): 99.8%
Beside the measured number, compound 4's estimate is 84.8 percentage points below it; measured number above the stated range.
By their numbers in this assay, from the lowest: compounds 2 and 1 (each within the scatter of the next); then compound 3; then compound 4.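

At this position, (4-cyanophenyl)sulfonyl is no loss against (2-phenylethenyl)carbonyl: a number 28.8 percentage points higher from compound 3 to compound 4 (beyond the scatter) in this assay shows that the (2-phenylethenyl)carbonyl group is not required for inhibition. Against (4-methylphenyl)carbonyl, the same sulfonyl group gives a number 102.3 percentage points higher from compound 2 to compound 4 (beyond the scatter) and so the widest step yet on this nitrogen. Nothing at hand explains this change.

Still open, from the compounds shown here alone, is whether the gain follows the sulfonyl or the 4-cyanophenyl part, as the two change together here. A methylsulfonyl or a (4-cyanophenyl)carbonyl group on this nitrogen would separate them.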